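The compounds below may be only part of what the source reports. "The series", "measured", "known", "first", "only" and "open" are said of these compounds alone.

Measured so far:

compound 1, `O=C(N/N=C\c1ccccc1)Nc1nnc(COc2ccc3ccccc3c2)o1`, in a functional assay on the whole organism (strain Swiss albino) with Mus musculus as the target, in the maximal electroshock model, with a stated time of 4 h (on this read-out lower numbers stand for an effect already at smaller amounts and higher numbers for an effect only at larger amounts of compound), gives 300 mg/kg
compound 2, `Cc1ccc(/C=N\NC(=O)Nc2nnc(COc3ccc4ccccc4c3)o2)cc1`, in this assay gives 300 mg/kg

These two compounds share one core and differ in a single place: a methyl in place of a hydrogen on an aromatic carbon, and that step, no change at the digits printed from compound 1 to compound 2 (within the scatter), left the read-out unchanged within the scatter. Compound 2 therefore stands level with compound 1 on the numbers shown, and nothing in the data so far separates the two.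

Compound 3, `CN(C)c1ccc(/C=N\NC(=O)Nc2nnc(COc3ccc4ccccc4c3)o2)cc1`, is the next compound in this series and has not yet been measured. It differs from compound 2 as follows: dimethylamino in place of methyl on an aromatic carbon. For the measured compounds named here, only one measured step bears on this change, the step from compound 1 to compound 2, and it was flat. Going by the values given here, that is a different group entering at the same position, so it is only a loose guide, but it is the single guide available. On that basis, the expected step is no change at the digits printed from compound 2 to compound 3 (within the scatter), that is, no change beyond the scatter. Compound 3 is therefore estimated to give 300 mg/kg in this assay, within the range from 100 mg/kg to 600 mg/kg.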

Compound 3, minimum effective dose: 300 mg/kg
The estimate for compound 3 equals the measured number at the digits printed, and the stated range covers the measured number.
By their numbers in this assay, from the lowest: compounds 1, 2 and 3 (each within the scatter of the next).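

Placing dimethylamino on this aromatic carbon, in the change from 4-methylphenyl to 4-(dimethylamino)phenyl, gives a flat result in this assay (no change at the digits printed from compound 2 to compound 3 (within the scatter)), and the same holds when dimethylamino is compared directly with hydrogen (no change at the digits printed from compound 1 to compound 3 (within the scatter)). For the compounds shown here, earlier, the only change seen here was methyl in place of hydrogen, a single carbon added; dimethylamino is larger, with three heavy atoms, and it brings in a nitrogen and a hydrogen-bond acceptor, yet the read-out still does not separate the compounds. So hydrogen, methyl and dimethylamino at this place, on a six-membered aromatic ring of carbon only and para to a large group, all fall within the scatter of one another, and no other measurement is available to say why.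

On these data alone, what remains open is whether a quite different group at this same carbon, such as a carboxylic acid, a chlorine atom or a longer alkyl chain, would move the value beyond the scatter. These three compounds also cannot show whether changes elsewhere on the shared core would affect this read-out.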